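Phenyl to benzyl on the shared core

The source may hold more compounds than are shown below. What is called first, only, known or untested is meant among the compounds shown, and "the series" means these compounds.

Measured in a functional assay on MCF7 cells (Homo sapiens) for antiproliferative activity, read by sulforhodamine B assay, with a stated time of 72 h (a higher number here means a weaker inhibitor, a lower number a stronger inhibitor), so far:
- compound 1 `O=C(Cn1nc(-c2ccccc2)c2ccccc2c1=O)Nc1ccccc1` gives 43000 nM
- compound 2 `O=C(Cn1nc(-c2ccccc2)c2ccccc2c1=O)Nc1ccccc1Cl` gives 30000 nM

Among the compounds with values here, only two numbers exist, and compound 1 cannot be separated from its one neighbour, with a 1.4-fold lower number from compound 1 to compound 2 (0.16 log units; within the scatter) as the whole spread. Compound 3 `O=C(Cn1nc(Cc2ccccc2)c2ccccc2c1=O)Nc1ccccc1` carries benzyl in place of phenyl on an aromatic carbon as its change from compound 1, that is, benzyl in place of phenyl on an aromatic carbon next to the ring nitrogen. Within the data shown here, the single measured step, chloro in place of hydrogen on an aromatic carbon, leaves that phenyl untouched, so it offers only a weak guide. Among the measured compounds shown here, no measured step covers this change. The expectation therefore stays with compound 1 at 43000 nM and no step beyond the scatter is expected in this assay in either direction. For compound 3 the estimated value is 40000 nM with an expected range from 15000 nM to 100000 nM on this basis. The estimate amounts to a 1.1-fold lower number from compound 1 to compound 3 (0.03 log units; within the scatter) as the expected step.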

Compound 3, half-maximal inhibitory concentration: 36000 nM
The estimate for compound 3 lay 1.1-fold (0.05 log units) above the measured number; low and high end bracket the measured number.
By their numbers in this assay, from the lowest: compounds 2, 3 and 1 (each within the scatter of the next).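

In this assay, benzyl in place of phenyl on the aromatic carbon next to the ring nitrogen gives a 1.2-fold lower number from compound 1 to compound 3 (0.08 log units; within the scatter). Within the data shown here, this is the first reading at this position, and it shows that this swap leaves the number inseparable from that of compound 1. No measurement is available that would account for the size of this step.

Going by these compounds, it remains open whether a different kind of group at this position, such as an amine, a carboxylic acid or a longer chain ending in phenyl, would give a step beyond the scatter. Also open, on these data alone, is whether chloro on the aromatic carbon changed in compound 2 would behave the same way with benzyl in place.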